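Series notes: aryl exchange on the shared core, compound 2 to 3

The source may hold more compounds than are shown below. What is called first, only, known or untested is meant among the compounds shown, and "the series" means these compounds.

Compound 1 `COc1cc(-c2cc(-c3cccc(O)c3)nc(-c3ccccc3)n2)cc(OC)c1OC` and compound 2 `COc1cc(-c2cc(-c3cccs3)nc(-c3ccccc3)n2)cc(OC)c1OC` share a core and differ only in one aryl group; compound 3 `COc1ccc(-c2cc(-c3cc(OC)c(OC)c(OC)c3)nc(-c3ccccc3)n2)cc1` carries a third variant at the same position. In a functional assay on MDA-MB-231 cells (Homo sapiens) for inhibition, read by MTT assay, with a stated time of 48 h (on this read-out lower numbers stand for stronger inhibition and higher numbers for weaker inhibition), compound 1 gives 1990 nM, and compound 2 gives 5110 nM; the change is a 2.6-fold higher number from compound 1 to compound 2 (0.41 log units; beyond the scatter). Among the measured compounds shown here, compound 2 thus stands with the highest number of the two measured, with compound 1 as its only neighbour.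

The change to compound 3 is 4-methoxyphenyl in place of thiophen-2-yl on an aromatic carbon. For the measured compounds named here, the only measured step that bears on it is the one from compound 1 to compound 2, where a six-membered aromatic ring of carbon was replaced by thiophen-2-yl and the number rose modestly; compound 3 reverses that direction in ring type, though with 4-methoxyphenyl rather than 3-hydroxyphenyl, for which no measured step exists. A move back toward the number of compound 1 is expected, with wide uncertainty; for compound 3 the expected step is a 1.7-fold lower number from compound 2 to compound 3 (0.23 log units; within the scatter), and its estimated value is 3000 nM with a range of 1000 nM to 9000 nM in this assay.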

Compound 3, half-maximal inhibitory concentration: 3390 nM
The estimate for compound 3 lay 1.1-fold (0.05 log units) below the measured number, within the range that was stated.
By their numbers in this assay, from the lowest: compounds 1, 3 and 2 (each within the scatter of the next, the first and the last beyond it).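

In this assay, the exchange of thiophen-2-yl for 4-methoxyphenyl gives a 1.5-fold lower number from compound 2 to compound 3 (0.18 log units; within the scatter), and the exchange of 3-hydroxyphenyl for 4-methoxyphenyl gives a 1.7-fold higher number from compound 1 to compound 3 (0.23 log units; within the scatter), so the third aryl group lies within the scatter of both others. The only gap beyond the scatter remains a 2.6-fold higher number from compound 1 to compound 2 (0.41 log units; beyond the scatter), and ring type alone does not sort the series: 4-methoxyphenyl, a six-membered aromatic ring of carbon like 3-hydroxyphenyl, cannot be told apart from either thiophen-2-yl or 3-hydroxyphenyl at this position. Nothing available accounts for these differences.

Still open, going by these compounds, is how a non-aromatic group at this position, such as an amine or a carboxylic acid, would read. Also open, on these data alone, is whether the hydroxy group of compound 1 matters apart from the ring that carries it.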